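The source may hold more compounds than are shown below. What is called first, only, known or untested is meant among the compounds shown, and "the series" means these compounds.

Measured in a physicochemical assay for lipophilicity, at pH 7.4; a higher number here means a more lipophilic compound, a lower number a more polar compound:
- compound 1 `C[C@H]1C(=O)N(C)C=Cc2ccccc21`: 4.3
- compound 2 `C[C@H]1C(=O)N(C)C=Cc2cc(CCO)ccc21`: 2.6

Of these two, compound 2 stands lowest, at 2.6, and the gap to compound 1 lies beyond the scatter. Compound 3 `C[C@H]1C(=O)N(C)C=Cc2cc(C(O)CO)ccc21` has not yet been measured. It differs from compound 2 in one place: hydroxy in place of hydrogen on a saturated chain carbon bound to an aromatic carbon and a saturated chain carbon. The 2-hydroxyethyl thus becomes 1,2-dihydroxyethyl.

Among the compounds with values here, only one measured step bears on this change: a number 1.70 log units lower from compound 1 to compound 2 (beyond the scatter). This large step came with 2-hydroxyethyl in place of hydrogen on an aromatic carbon. Within the data shown here, it brought in a whole chain, not a hydroxy alone, so it is only a loose guide, and no measured step shows the effect of a further hydroxy. Going by that one step, the expected change is a number 0.90 log units lower from compound 2 to compound 3 (beyond the scatter), in the same direction but smaller, and beyond the scatter. For compound 3 the estimate is 1.7, with an expected range of 1.2 to 2.2.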

Compound 3, distribution coefficient: 1.1
The estimate for compound 3 lay 0.60 log units above the measured number; measured number outside the range, below it.
By their numbers in this assay, from the lowest: compound 3; then compound 2; then compound 1.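

In this assay, a single hydroxy on the saturated chain carbon bound to an aromatic carbon and a saturated chain carbon gives a number 1.50 log units lower from compound 2 to compound 3 (beyond the scatter), so one added group on a chain already carrying a hydroxy still produces a large step. That step is also large beside the one that brought in the whole 2-hydroxyethyl, and taken together the two changes give a number 3.20 log units lower from compound 1 to compound 3 (beyond the scatter) on the shared core. Nothing measured here accounts for the size of this drop.

On these data alone, it remains open whether an amine or a carboxylic acid in place of the new hydroxy would shift the number as far. As far as these compounds go, it is equally open whether a longer chain bearing further hydroxy groups would continue the same downward run.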